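Adding fluoro to compound 2

This account rests on a few compounds, and the source may have more. Where it says the series, first, only, none or still open, it means among the compounds named here.

Values in a functional assay on MCF7 cells (Homo sapiens) for cytotoxicity, read by MTT assay, with a stated time of 48 h (a lower number here means a stronger inhibitor, a higher number a weaker inhibitor), are as follows:
- compound 1 `O=C(/C=C/c1cccc(F)c1)Nc1ccc(CC2=CC(=O)OC2)cc1` gives 39000 nM
- compound 2 `C=C1OC(=O)C=C1Cc1ccc(NC(=O)/C=C/c2ccccc2)cc1` gives 9490 nM
- compound 3 `C=C1OC(=O)C=C1Cc1ccc(NC(=O)c2ccccc2)cc1` gives > 50000 nM as a limit of the assay

Of the two numeric values, compound 2 is lowest at 9490 nM and compound 1 is nearest at 39000 nM beyond the scatter. Compound 4 `C=C1OC(=O)C=C1Cc1ccc(NC(=O)/C=C/c2cccc(F)c2)cc1` differs from compound 2 by fluoro in place of hydrogen on an aromatic carbon with fluoro in place of hydrogen on an aromatic carbon. For the measured compounds named here, the one measured step, an at least 5.2-fold higher number from compound 2 to compound 3 (0.72 log units; beyond the scatter), changes the group on a carbonyl carbon and bears only loosely on this. Compound 1 carries the same 3-fluorophenyl on a different core, so its 39000 nM does not isolate the fluoro. The expected step is a 1.1-fold higher number from compound 2 to compound 4 (0.02 log units; within the scatter) in this assay and no change beyond the scatter is expected. Compound 4 is estimated at 10000 nM with an expected range from 4500 nM to 25000 nM as a working figure.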

Compound 4, half-maximal inhibitory concentration: 39000 nM
Compound 4: the middle estimate sits 3.9-fold (0.59 log units) below what was measured, and the stated range ends below it.
By their numbers in this assay, from the lowest: compound 2; then compounds 1 and 4 (each within the scatter of the next). At a limit, above all of these: compound 3.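

In this assay, fluoro in place of hydrogen on the aromatic ring is not a silent change in this series: a 4.1-fold higher number from compound 2 to compound 4 (0.61 log units; beyond the scatter). With 3-fluorophenyl present, the two ring groups on the saturated chain carbon cannot be told apart, with no change at the digits printed from compound 1 to compound 4 (within the scatter). For the compounds shown here, the only measurement available that could speak to a cause is a limit on a different change, so it gives no reason for the fluoro step.

Going by these compounds, whether chloro, methoxy or an amine at this place gives a similar step remains open. So does whether the two ring groups also match with plain phenyl.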